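Notes on the amide tail, compound 2 to compound 4

The source may hold more compounds than are shown below. What is called first, only, known or untested is meant among the compounds shown, and "the series" means these compounds.

Of the compounds shown here, three have been measured in a functional assay on HT-29 cells (Homo sapiens) for cytotoxicity, read by MTT assay, with a stated time of 24 h, tested at 1.6 ug/mL; on this read-out higher numbers stand for a stronger effect at the one concentration tested and lower numbers for a weaker effect. Compound 1 `Cn1c(-c2ccc(NC(=O)CSc3nc4ccccc4o3)cc2)nc(-c2ccccc2)c1-c1ccccc1` gives 41%, compound 2 `Cn1c(-c2ccc(NC(=O)CSc3nc4ccccc4s3)cc2)nc(-c2ccccc2)c1-c1ccccc1` gives 15.3%, and compound 3 `Cn1c(-c2ccc(NC(=O)CSC3=NCCS3)cc2)nc(-c2ccccc2)c1-c1ccccc1` gives 30.4%. Compound 2 stands lowest of the three: compound 3 lies a number 15.1 percentage points higher from compound 2 to compound 3 (beyond the scatter), and compound 1 lies further still, as a number 25.7 percentage points lower from compound 1 to compound 2 (beyond the scatter) shows in the other direction.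

Compound 4 `Cn1c(-c2ccc(NC(=O)CN3CCN(c4ccccc4)CC3)cc2)nc(-c2ccccc2)c1-c1ccccc1` differs from compound 2 by 4-phenylpiperazin-1-yl in place of (1,3-benzothiazol-2-yl)sulfanyl on a saturated chain carbon bound to a carbonyl carbon. The measured steps bear only loosely on this change. Both known steps swapped the group on a sulfur while keeping the sulfanyl link: benzothiazolyl for benzoxazolyl gave a number 25.7 percentage points lower from compound 1 to compound 2 (beyond the scatter), and the five-membered non-aromatic ring for the benzothiazolyl gave a number 15.1 percentage points higher from compound 2 to compound 3 (beyond the scatter). Nothing measured yet removes the sulfur and puts a nitrogen ring directly on the chain carbon, so the direction of the step in this assay rests on the fact that compound 2 is the lowest point seen and every change from it so far has gone upward.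

A modest rise is therefore expected, a number 14.7 percentage points higher from compound 2 to compound 4 (beyond the scatter), with wide uncertainty. Compound 4 is estimated at 30%, within 12% to 52%.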

Compound 4, a percentage reported as activity, at one concentration (the size of the read-out at that concentration, not a potency): 26%
For compound 4 the middle estimate is 4 percentage points above the measured one, within the range that was stated.
By their numbers in this assay, from the lowest: compound 2; then compounds 4 and 3 (each within the scatter of the next); then compound 1.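

The first replacement of the sulfanyl link shows that sulfur on the saturated chain carbon bound to a carbonyl carbon is not required for a read-out in this assay: 4-phenylpiperazin-1-yl gives a number 10.7 percentage points higher from compound 2 to compound 4 (beyond the scatter), yet also a number 15 percentage points lower from compound 1 to compound 4 (beyond the scatter), so the same change reads upward or downward depending on the group it replaces. With a number 4.4 percentage points lower from compound 3 to compound 4 (within the scatter), the sulfur-free group and the sulfur-linked five-membered non-aromatic ring cannot be told apart at this position, although they differ in size and in their atoms. The data hold no measurement that would explain any of these steps.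

On these data alone, the step from compound 2 to compound 4 changes the link atom and the whole ring system at once, so the share of each remains unknown; a morpholine or an unsubstituted piperazine on the same chain carbon, or a benzothiazol-2-yl group joined through an amine nitrogen instead of sulfur, would begin to separate them. All of these numbers also come from a single concentration, which leaves the potency order of the four compounds open.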